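Sulfamoylphenyl in Place of Cyanophenyl: Expected Efficacy Step

The source may report more compounds than this note shows. Statements on the series, on what has been measured and on what is new or still open speak of the compounds shown alone.

Three compounds have been measured in an in vitro functional assay on HEK285-7 cells for antagonist activity at prostaglandin D2 receptor 2 (Homo sapiens), read by BRET and beta-arrestin recruitment; on this read-out higher numbers stand for larger maximal responses and lower numbers for smaller maximal responses:

Compound 1, `COc1cc(-c2nc(C(c3ccc(F)cc3)c3ccc(F)cc3)sc2CC(=O)O)ccn1`: 60%
Compound 2, `O=C(O)Cc1sc(C(c2ccc(F)cc2)c2ccc(F)cc2)nc1-c1ccnc(N2CCCC2)c1`: 80%
Compound 3, `N#Cc1ccc(-c2nc(C(c3ccc(F)cc3)c3ccc(F)cc3)sc2CC(=O)O)cc1`: 30%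

Compound 3 stands lowest of the three, below compound 1 and further below compound 2. Both earlier steps concern the aryl group on the shared core: a number 30 percentage points lower from compound 1 to compound 3 (beyond the scatter) and a number 50 percentage points lower from compound 2 to compound 3 (beyond the scatter). They show that this aryl group moves efficacy by modest to large amounts.

Compound 4 is `NS(=O)(=O)c1cccc(-c2nc(C(c3ccc(F)cc3)c3ccc(F)cc3)sc2CC(=O)O)c1`. Compared with compound 3, (3-sulfamoylphenyl in place of 4-cyanophenyl on an aromatic carbon). Among the compounds with values here, no measured step involves a 3-sulfamoylphenyl group, so the direction rests only on the observation that compound 3 is the lowest number and that aryl changes have shifted efficacy. Compound 4 is therefore expected to show a number 15 percentage points higher from compound 3 to compound 4 (beyond the scatter), a modest rise. The estimate for compound 4 is 45%, with a range from 20% to 75%.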

Compound 4, largest response reached (reported as efficacy), in percent of the reference or control that the assay uses: 55%
For compound 4 the middle estimate is 10 percentage points below the measured one; the range from low to high includes it.
By their numbers in this assay, from the lowest: compound 3; then compounds 4 and 1 (each within the scatter of the next); then compound 2.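

Compound 4 shows that a carbon-only aromatic ring on this carbon need not give the low response of compound 3: the 3-sulfamoylphenyl group brings a number 25 percentage points higher from compound 3 to compound 4 (beyond the scatter) in place of 4-cyanophenyl. Set against the pyridinyl groups, it gives a number 25 percentage points lower from compound 2 to compound 4 (beyond the scatter) for 2-(pyrrolidin-1-yl)pyridin-4-yl and a number 5 percentage points lower from compound 1 to compound 4 (within the scatter) for 2-methoxypyridin-4-yl, so compound 4 sits level with compound 1 and not with compound 2. No evidence is available on why the response moves.

On these data alone, whether the rise follows the sulfamoyl group or its place on the phenyl ring stays open. A 3-cyanophenyl or 4-sulfamoylphenyl group would separate the two.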